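An Amide in Place of an Aryl Amine on the Core

This account rests on a few compounds, and the source may have more. Where it says the series, first, only, none or still open, it means among the compounds named here.

Of the compounds shown here, three sharing one core have been measured. In an assay on isolated protein for inhibition of G protein-coupled receptor kinase 5 (Homo sapiens), read by TR-FRET, with stated times of 10 min and 1 h (a higher number here means a weaker inhibitor, a lower number a stronger inhibitor), compound 1 `Nc1ncc(-c2cnn(C3CCNCC3)c2)cc1-c1nc2cc(Nc3ccccc3)ccc2o1` gives 3500 nM. Compound 2 `Nc1ncc(-c2cnn(C3CCNCC3)c2)cc1-c1nc2ccc(Nc3ccc(F)cc3)cc2o1` gives 3700 nM in this assay, and compound 3 `Nc1ncc(-c2cnn(C3CCNCC3)c2)cc1-c1nc2ccc(Oc3ccccc3)cc2o1` gives 4000 nM. Compound 2 lies within the usual scatter of both compound 1 and compound 3, so the three numbers cannot be told apart. For the measured compounds named here, the single step that changes one place, a 1.1-fold higher number from compound 2 to compound 3 (0.03 log units; within the scatter), exchanges phenoxy for (4-fluorophenyl)amino on an aromatic carbon and stays within the scatter.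

Compound 4 `COc1ccc(C(=O)Nc2ccc3nc(-c4cc(-c5cnn(C6CCNCC6)c5)cnc4N)oc3c2)cc1` has not yet been measured. It differs from compound 2 by (4-methoxyphenyl)carbonyl in place of 4-fluorophenyl on a nitrogen on an aromatic ring, so the nitrogen on the aromatic ring now carries a carbonyl-linked group rather than an aromatic ring directly. Going by the values given here, no measured step touches this change. Among the compounds with values here, the only step at hand, a 1.1-fold higher number from compound 2 to compound 3 (0.03 log units; within the scatter), shows that a change in this region passed without movement beyond the scatter, but it does not involve a carbonyl. The expected step of a 1.1-fold higher number from compound 2 to compound 4 (0.03 log units; within the scatter) is therefore small, with wide uncertainty. Compound 4 is estimated at 4000 nM in this assay, between 1500 nM and 12000 nM.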

Compound 4, half-maximal inhibitory concentration: 2090 nM
Estimate against measurement, compound 4: 1.9-fold (0.28 log units) above; the measured number falls inside the stated range.
By their numbers in this assay, from the lowest: compounds 4, 1, 2 and 3 (each within the scatter of the next).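

With a carbonyl now linking the aromatic ring to the nitrogen, this assay shows a 1.8-fold lower number from compound 2 to compound 4 (0.25 log units; within the scatter), and the wider exchange of the whole group on the aromatic carbon shows a 1.9-fold lower number from compound 3 to compound 4 (0.28 log units; within the scatter). The earlier compounds shown here covered only an aromatic ring joined directly through nitrogen or oxygen, whereas these steps show that an amide at this position, with its larger group and a double bond outside the aromatic rings, also leaves the number within the scatter. Nothing at hand explains why the numbers stay so close.

Compound 4 brings in the carbonyl and replaces fluorine with methoxy in a single change, so the compounds shown cannot separate the two. Going by these compounds, whether a sulfonyl link or a plain acetyl group on this nitrogen would move the number beyond the scatter remains open.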